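Adding a Methoxy Group to a Weak Antiproliferative Pyrazoline

The source may hold more compounds than are shown below. What is called first, only, known or untested is meant among the compounds shown, and "the series" means these compounds.

Compound 2 `Cn1c(N2N=C(c3ccc(Cl)cc3)CC2c2ccccc2)nc(-c2ccccc2)c(C#N)c1=O` is the weaker of two measured compounds. In a functional assay on A549 cells (Homo sapiens) for antiproliferative activity, with a stated time of 72 h (a lower number here means a stronger inhibitor, a higher number a weaker inhibitor), compound 2 gives 26900 nM, the highest of the two numbers. Its nearest neighbour, compound 1 `COc1ccc(C2CC(c3ccccc3)=NN2c2nc(-c3ccccc3)c(C#N)c(=O)n2C)cc1`, gives 1760 nM in this assay, a markedly lower number, a gap that lies beyond the usual scatter. Within the data shown here, compound 1 and compound 2 differ in more than one place, so their two values show only that compound 1 is the stronger inhibitor, without telling which of the differences carries the effect.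

Compound 3 `COc1ccc(C2CC(c3ccc(Cl)cc3)=NN2c2nc(-c3ccccc3)c(C#N)c(=O)n2C)cc1` has not yet been measured. It differs from compound 2 by one change: methoxy in place of hydrogen on an aromatic carbon. Compound 3 thereby carries the methoxy group that compound 1 has and keeps the chlorine that compound 2 has.

Among the measured compounds shown here, because compound 1, the only measured compound bearing that methoxy group, gives 1760 nM, the step from compound 2 to compound 3 is expected to be toward a lower number, a 4.5-fold lower number from compound 2 to compound 3 (0.65 log units; beyond the scatter), though not necessarily as far as compound 1. For compound 3 the estimate in this assay is 6000 nM, within a range of 1800 nM to 20000 nM.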

Compound 3, half-maximal inhibitory concentration: 6070 nM
Compound 3: middle estimate off by 1.0-fold (0.01 log units), on the low side, and the stated range covers the measured number.
By their numbers in this assay, from the lowest: compound 1; then compound 3; then compound 2.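

In this assay, the step of a 4.4-fold lower number from compound 2 to compound 3 (0.65 log units; beyond the scatter) isolates methoxy in place of hydrogen on an aromatic carbon, para to a large group, and shows that this single change, phenyl to 4-methoxyphenyl, lowers the number beyond the scatter while the chlorine stays in place. The second single change, chloro in place of hydrogen on an aromatic carbon, gives a 3.4-fold higher number from compound 1 to compound 3 (0.54 log units; beyond the scatter) and also lies beyond the scatter, so the gap between compound 1 and compound 2, which could not be divided before, now has two modest parts that point the same way: the methoxy group goes with a lower number and the chlorine with a higher one. Nothing measured on these compounds gives a reason for either step.

On these data alone, whether the methoxy group is the best choice on this ring stays open, since a hydroxyl group, an amine or a longer chain such as butoxy could give a lower or a higher number at the same place. As far as these compounds go, it is also open whether the two steps would keep their size on a compound with neither the methoxy group nor the chlorine.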